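Replacing the linker of compound 1: an expectation

The compounds below may be only part of what the source reports. "The series", "measured", "known", "first", "only" and "open" are said of these compounds alone.

Compounds measured so far:
compound 1, `CN(C)C(=O)c1cc2cnc(Nc3ccc(S(=O)(=O)NCCCCCN=C=S)cc3)nc2n1C1CCCC1`, 52.1%
compound 2, `CN(C)C(=O)c1cc2cnc(Nc3ccc(S(=O)(=O)NCCCCCCN=C=S)cc3)nc2n1C1CCCC1`, 42.4%
compound 3, `CN(C)C(=O)c1cc2cnc(Nc3ccc(S(=O)(=O)NCCCCCCCN=C=S)cc3)nc2n1C1CCCC1`, 58.9%

All three were tested in a functional assay on NCI-H1299 cells (Homo sapiens) for inhibition, read by CCK-8 assay, with a stated time of 72 h, tested at 1 uM; on this read-out lower numbers stand for a weaker effect and higher numbers for a stronger effect at the one concentration tested. Compound 1 stands second highest of the three numbers; its nearest neighbour is compound 3, a number 6.8 percentage points higher from compound 1 to compound 3 (within the scatter), and its furthest is compound 2, a number 9.7 percentage points lower from compound 1 to compound 2 (within the scatter), both within the scatter. For the measured compounds named here, only the step of a number 16.5 percentage points higher from compound 2 to compound 3 (beyond the scatter) lies beyond it.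

Compound 4, `CN(C)C(=O)c1cc2cnc(Nc3ccc(NC(=O)CCCCCN=C=S)cc3)nc2n1C1CCCC1`, has not been measured. It differs from compound 1 by a group of 11 heavy atoms (7 carbon, 2 nitrogen, 1 oxygen, 1 sulfur; no ring) in place of a group of 12 heavy atoms (6 carbon, 2 nitrogen, 2 oxygen, 2 sulfur; no ring), on an aromatic carbon. The three measured steps all alter the group on a saturated chain carbon five or six bonds from a sulfonamide nitrogen, lengthening the chain, and none of them changes the group on the aromatic carbon itself. They therefore bear on this step only loosely: they show that changes in that region of the molecule moved the read-out little, mostly within the scatter. Going by the values given here, no measured pair tests the exchange made here.

On that basis the author expects no step beyond the scatter, a number 2.1 percentage points lower from compound 1 to compound 4 (within the scatter), and estimates for compound 4 a value of 50%, between 30% and 70%.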

Compound 4, a percentage reported as inhibition, at one concentration (the size of the read-out at that concentration, not a potency): 34.3%
For compound 4 the middle estimate is 15.7 percentage points above the measured one, within the range that was stated.
By their numbers in this assay, from the lowest: compounds 4, 2, 1 and 3 (each within the scatter of the next, the first and the last beyond it).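

In this assay, the exchange on the aromatic carbon, para to a large group, gives a number 17.8 percentage points lower from compound 1 to compound 4 (beyond the scatter) and so reaches beyond the scatter. For the compounds shown here, this shows that the read-out responds to the link itself, with the group of 11 heavy atoms carrying an amide in place of the group of 12 heavy atoms carrying the sulfonamide, whereas the earlier steps only lengthened the chain and kept the sulfonamide, and among them only a number 16.5 percentage points higher from compound 2 to compound 3 (beyond the scatter) passed the scatter. No measurement at hand accounts for this step.

From the compounds shown here alone, whether the amide link would give the same picture with a longer chain, or with an acrylamide in place of the isothiocyanate, remains open. Going by these compounds, since each compound was read at one concentration, how the potencies of compound 1 and compound 4 compare also stays unknown.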